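Swapping fluoro for hydroxy on a retinoid-like amide

The compounds below may be only part of what the source reports. "The series", "measured", "known", "first", "only" and "open" are said of these compounds alone.

Compound 1 `CC1=C(/C=C/C(C)=C/C=C/C(C)=C\C(=O)NCc2ccc(F)cc2)C(C)(C)CCC1n1ccnc1` has the lower of the two numbers measured in a functional assay on MDA-MB-231 cells (Homo sapiens) for inhibition, read by MTT assay; a higher number here means a weaker inhibitor of growth, a lower number a stronger inhibitor of growth: compound 1 gives 1410 nM. Compound 2 `CC1=C(/C=C/C(C)=C/C=C/C(C)=C\C(=O)NCc2ccc(O)cc2)C(C)(C)CC=C1c1cncnc1`, built on a different core, gives 11500 nM in this assay, a gap beyond the usual scatter. Compound 3 `CC1=C(/C=C/C(C)=C/C=C/C(C)=C\C(=O)NCc2ccc(O)cc2)C(C)(C)CCC1n1ccnc1` keeps the core of compound 1 and differs from it in one place: hydroxy in place of fluoro on an aromatic carbon. Among the compounds with values here, no measured pair isolates this change, so the expected step from compound 1 to compound 3, a 2.1-fold higher number from compound 1 to compound 3 (0.33 log units; beyond the scatter), is a modest weakening near the edge of the scatter. Compound 3 is expected to give about 3000 nM in this assay, between 1000 nM and 9000 nM.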

Compound 3, concentration for 50% growth inhibition: 2230 nM
Estimate against measurement, compound 3: 1.3-fold (0.13 log units) above; the measured number falls inside the stated range.
By their numbers in this assay, from the lowest: compounds 1 and 3 (each within the scatter of the next); then compound 2.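

On the core of compound 1, the 4-fluorobenzyl group can give way to the 4-hydroxybenzyl group, with a 1.6-fold higher number from compound 1 to compound 3 (0.20 log units; within the scatter) in this assay. This position therefore accepts hydroxy, which adds a hydrogen-bond donor and acceptor that fluoro lacks, without moving the number beyond the scatter. Nothing available explains why this swap is tolerated. Still open, as far as these compounds go, is whether an amine or a methoxy group on the same aromatic carbon would also stay within the scatter, and whether fluoro would match hydroxy on the core of compound 2.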